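The source may report more compounds than this note shows. Statements on the series, on what has been measured and on what is new or still open speak of the compounds shown alone.

Measured in a functional assay on SW1573 cells (Homo sapiens) for antiproliferative activity, read by sulforhodamine B assay, with a stated time of 48 h; a higher number here means a weaker inhibitor of growth, a lower number a stronger inhibitor of growth:

- compound 1 `CC(C)(C)[Si](C)(C)O[C@@H]1CCCO[C@@H]1/C=C/C(=O)OCc1ccccc1`: 37000 nM
- compound 2 `COC(=O)/C=C\[C@H]1OCCC[C@H]1O[Si](C)(C)C(C)(C)C`: 6300 nM
- compound 3 `CC(C)(C)[Si](C)(C)O[C@@H]1CCCO[C@@H]1/C=C\CO`: > 100000 nM

Compound 3 stands at a limit of this assay, which is not a true number: the limit of > 100000 nM in this assay, at which 1 of the 3 values shown sits. The next compound, compound 4 `CC(C)(C)[Si](C)(C)O[C@@H]1CCCO[C@@H]1/C=C/C(=O)O`, differs from it on a saturated ring carbon, next to the ring oxygen: 2-carboxyethenyl in place of 3-hydroxyprop-1-en-1-yl on a saturated ring carbon. In words, 2-carboxyethenyl takes the place of 3-hydroxyprop-1-en-1-yl.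

Going by the values given here, one measured step bears on this change: an at least 15-fold higher number from compound 2 to compound 3 (1.20 log units; beyond the scatter). That large step came with the loss of methoxycarbonyl, and compound 4 brings a carboxy group back to the chain. A step to a lower number in this assay is therefore expected, meaning stronger growth inhibition. Among the compounds with values here, no measured compound carries a free carboxy group, however, so the step may be modest, and another limit is possible.

The estimate means an at least 2.0-fold lower number from compound 3 to compound 4 (0.30 log units; that floor lies within the scatter), an expected move that remains uncertain in size. For compound 4 the expected value is 50000 nM, with an estimated range from 15000 nM to 100000 nM.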

Compound 4, concentration for 50% growth inhibition: > 100000 nM
Compound 4 ended at the assay's limit (the forecaster's own chance of this, stated with the estimate: 40%); middle value at least 2.0-fold (0.30 log units) from the limit.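

In this assay, compound 4 stands at a limit, not a true number: the limit of > 100000 nM in this assay, at which 2 of the 4 values shown sit.

Freeing the carboxy group therefore does not keep the growth inhibition seen with the esters: hydrogen in place of benzyl gives an at least 2.7-fold higher number from compound 1 to compound 4 (0.43 log units; beyond the scatter), and 2-carboxyethenyl in place of 2-(methoxycarbonyl)ethenyl gives an at least 15-fold higher number from compound 2 to compound 4 (1.20 log units; beyond the scatter), both beyond the scatter. The step between the alcohol compound 3 and the acid compound 4 cannot be read, with a limit on both sides, so these two chain ends cannot be ranked against each other.

Going by these compounds, what stays open is whether an amide or a larger ester at the end of this chain would bring back a measurable value. The compounds shown also leave open how far beyond the limit compound 3 and compound 4 truly lie.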